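A few compounds are considered here, and "the series" means these few. Any claim that something is new, unique, unknown or untested is made for them only; others in the source may bear on it.

Measured in an ADME assay on MRC5 cells (Homo sapiens) for cytotoxicity, read by resazurin assay, with a stated time of 7 days; a lower number here means that less compound is tolerated, a higher number that more compound is tolerated:
Compound 1 `COc1cccc(NC(=O)Nc2ccc3nc(Oc4ccc(F)cc4C(C)O)c(Cc4ccccc4)cc3c2)c1`: 64000 nM
Compound 2 `CC(c1cc(F)ccc1Oc1nc2ccc(-n3cc(-c4ccccc4)nn3)cc2cc1Cc1ccccc1)n1ccnc1`: 64000 nM

On these numbers, compound 1 stands level with compound 2, with nothing between them beyond the scatter. Compound 3 `COc1ccc(NC(=S)Nc2ccc3nc(Oc4ccc(F)cc4C(C)O)c(Cc4ccccc4)cc3c2)cc1` departs from compound 1 in one place, on a nitrogen on an aromatic ring: a group of 11 heavy atoms (8 carbon, 1 nitrogen, 1 oxygen, 1 sulfur; one six-membered aromatic ring of carbon only) in place of a group of 11 heavy atoms (8 carbon, 1 nitrogen, 2 oxygen; one six-membered aromatic ring of carbon only), on a nitrogen on an aromatic ring. Within the data shown here, no measured pair shows what such a change does, so the expectation is only tentative: a modest move towards less compound being tolerated in this assay, possibly none beyond the scatter. The expected change is a 1.8-fold lower number from compound 1 to compound 3 (0.26 log units; within the scatter). For compound 3 the estimate is 35000 nM, with an expected range from 9000 nM to 70000 nM.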

Compound 3, half-maximal cytotoxic concentration: 42300 nM
Compound 3: middle estimate off by 1.2-fold (0.08 log units), on the low side; low and high end bracket the measured number.
By their numbers in this assay, from the lowest: compounds 3, 1 and 2 (each within the scatter of the next).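

In this assay, among these compounds, this is the first pair of compounds that differ in one place, and the step is a 1.5-fold lower number from compound 1 to compound 3 (0.18 log units; within the scatter). On a nitrogen on an aromatic ring, then, the sulfur-bearing group of compound 3 can take the place of (3-methoxyphenyl)carbamoyl without a shift beyond the scatter. Nothing available offers an explanation of this result.

Among the compounds shown here, the single step cannot separate any contribution of the sulfur from that of the placing of the methoxy group. On these data alone, whether a simple amine or a carboxylic acid at this nitrogen would give a larger shift remains open.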